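Series notes on acid half-life: the step to compound 3

The source may hold more compounds than are shown below. What is called first, only, known or untested is meant among the compounds shown, and "the series" means these compounds.

Compound 1, `N[C@@H](CSNC(=O)[C@@H](CCC(F)(F)F)N(Cc1ccc(-c2ncon2)cc1F)S(=O)(=O)c1ccc(Cl)cc1)C(=O)O`: in a physicochemical assay for pharmacokinetics, at pH 1, tested at 100 ug/mL (a higher number here means that the compound lasts longer, a lower number that the compound disappears faster), compound 1 gives > 500 h, which is a limit of the assay.
Compound 2, `O=C(NSc1ccccc1)[C@@H](CCC(F)(F)F)N(Cc1ccc(-c2ncon2)cc1F)S(=O)(=O)c1ccc(Cl)cc1`: in this assay compound 2 gives > 500 h, again a limit of the assay.

For the measured compounds named here, compound 2 therefore stands at the upper limit of this assay, with only a limit known for it, and the one further value is a limit as well. Going by the values given here, the single measured step, a step that the two limits leave unreadable from compound 1 to compound 2, cannot be read in size because of the limit of > 500 h in this assay, at which 2 of the 2 values shown sit.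

Compound 3, `N#CCCSNC(=O)[C@@H](CCC(F)(F)F)N(Cc1ccc(-c2ncon2)cc1F)S(=O)(=O)c1ccc(Cl)cc1`, is the next change from compound 2: 2-cyanoethyl in place of phenyl on a sulfur. Among the compounds with values here, no measured step bears on this change in a readable way, since both values in hand sit at the same limit. The expected step, a step that the limit leaves unreadable from compound 2 to compound 3, is none beyond the scatter, and compound 3 is most likely to return a limit once more. Compound 3 is estimated at 600 h in this assay, with an expected range from 250 h to 2000 h.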

Compound 3, half-life: > 500 h
Compound 3: a limit, no number (the forecaster's own chance of this, stated with the estimate: 85%); the middle value does not contradict the limit.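

No step among compound 1, compound 2 and compound 3 can be read in this assay, because all three values are the same limit of the assay: the limit of > 500 h in this assay, at which 3 of the 3 values shown sit.

The compounds shown leave open whether phenyl, 2-cyanoethyl and 2-amino-2-carboxyethyl on the sulfur differ at all in half-life in this assay.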